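The source may report more compounds than this note shows. Statements on the series, on what has been measured and on what is new or still open speak of the compounds shown alone.

Measured so far in an assay on isolated protein for inhibition of coagulation factor X (Oryctolagus cuniculus), tested at 1 uM; on this read-out lower numbers stand for less inhibition and higher numbers for more inhibition at the one concentration tested (going by the name of the read-out):
compound 1 `O=C1[C@@H](NS(=O)(=O)c2ccc(-c3ccon3)s2)CCN1Cc1cc2cc[nH]cc-2n1` gives 49%
compound 2 `O=C1[C@@H](NS(=O)(=O)c2ccc(-c3ccccn3)s2)CCN1Cc1cc2c[nH]ccc-2n1` gives 11%

Compound 2 is the lowest of the two numbers; compound 1 stands above it by a margin beyond the usual scatter. Going by the values given here, compound 1 and compound 2 differ in more than one place, so no single step between them is isolated. Compound 3 `O=C1[C@@H](NS(=O)(=O)c2ccc(-c3ccccn3)s2)CCN1Cc1cc2cc[nH]cc-2n1` keeps the rest of compound 2 and alters one end: a group of 9 heavy atoms (7 carbon, 2 nitrogen; one five-membered aromatic ring with 1 hetero atom, one six-membered aromatic ring with 1 hetero atom) in place of a group of 9 heavy atoms (7 carbon, 2 nitrogen; one five-membered aromatic ring with 1 hetero atom, one six-membered aromatic ring with 1 hetero atom), on a saturated chain carbon bound to an amide-type nitrogen in a ring. Among the compounds with values here, no measured step covers this change, so in this assay a step of moderate size is expected, direction uncertain, leaning upward. Compound 3 is estimated at 28%, between 5% and 60%, which corresponds to a step of a number 17 percentage points higher from compound 2 to compound 3 (beyond the scatter).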

Compound 3, a percentage reported as inhibition, at one concentration (the size of the read-out at that concentration, not a potency): 17%
The estimate for compound 3 lay 11 percentage points above the measured number, and the stated range covers the measured number.
By their numbers in this assay, from the lowest: compounds 2 and 3 (each within the scatter of the next); then compound 1.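

In this assay, the two arrangements of the same atoms on the saturated chain carbon are not separated (a number 6 percentage points higher from compound 2 to compound 3 (within the scatter)). With that end held fixed, the large step lies at the other end, where pyridin-2-yl stands in place of 1,2-oxazol-3-yl on an aromatic carbon (a number 32 percentage points lower from compound 1 to compound 3 (beyond the scatter)). No evidence on the cause of either step is at hand.

On these data alone, whether phenyl on that aromatic carbon would read nearer compound 1 or compound 3 remains open. Also open, as far as these compounds go, is whether 1,2-oxazol-3-yl gives a similar number when paired with the group of compound 2.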